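A few compounds are considered here, and "the series" means these few. Any claim that something is new, unique, unknown or untested is made for them only; others in the source may bear on it.

Measured compounds:
- compound 1, `O=C1c2ccccc2S(=O)(=O)N1CCCCCN1CCN(c2ccccc2)CC1`, giving 148 nM in an assay on HEK293 cells for displacement of a labelled ligand from 5-hydroxytryptamine receptor 7 (Homo sapiens); a lower number here means a stronger inhibitor, a higher number a weaker inhibitor
- compound 2, `COc1ccccc1N1CCN(CCCCCN2C(=O)c3ccccc3S2(=O)=O)CC1`, giving 125 nM in this assay
- compound 3, `O=C1c2ccccc2S(=O)(=O)N1CCCCCN1CCN(c2ncccn2)CC1`, giving 2670 nM in this assay

Compound 3 has the highest number of the three in this assay, which means it is the weakest inhibitor of the group; the step of an 18-fold higher number from compound 1 to compound 3 (1.26 log units; beyond the scatter) and the step of a 21-fold higher number from compound 2 to compound 3 (1.33 log units; beyond the scatter) both lie beyond the scatter, so the gap is real. Compound 4, `O=C1c2ccccc2S(=O)(=O)N1CCCCCN1CCN(c2cccc(C(F)(F)F)c2)CC1`, has not yet been measured. It differs from compound 3 in one place: 3-(trifluoromethyl)phenyl in place of pyrimidin-2-yl on an amine nitrogen in a ring. The two measured steps that bear on this change both run in the opposite direction, from a phenyl or a 2-methoxyphenyl on that ring nitrogen to the pyrimidin-2-yl, and both were large, as an 18-fold higher number from compound 1 to compound 3 (1.26 log units; beyond the scatter) and a 21-fold higher number from compound 2 to compound 3 (1.33 log units; beyond the scatter) show. Compound 4 returns a ring of carbon only to that nitrogen, carrying a trifluoromethyl group, and a drop in number of a similar size is therefore expected, close to where compound 1 stands. The expected step is a 15-fold lower number from compound 3 to compound 4 (1.17 log units; beyond the scatter). For compound 4 the estimate in this assay is 180 nM, with a range from 60 nM to 540 nM.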

Compound 4, inhibition constant: 35 nM
Compound 4: middle estimate off by 5.1-fold (0.71 log units), on the high side; the measured number lies below the stated range.
By their numbers in this assay, from the lowest: compound 4; then compounds 2 and 1 (each within the scatter of the next); then compound 3.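

For the compounds shown here, compound 4 is the only compound here that falls clearly below compound 1 and compound 2 in this assay, so a carbon-only ring on the amine nitrogen does more than recover the ground lost with pyrimidin-2-yl (a 76-fold lower number from compound 3 to compound 4 (1.88 log units; beyond the scatter)). The substituent on that phenyl also matters: trifluoromethyl gives a modest gain over plain phenyl (a 4.2-fold lower number from compound 1 to compound 4 (0.63 log units; beyond the scatter)) and over 2-methoxyphenyl (a 3.6-fold lower number from compound 2 to compound 4 (0.55 log units; beyond the scatter)), whereas the step from phenyl to 2-methoxyphenyl stays within the scatter (a 1.2-fold lower number from compound 1 to compound 2 (0.07 log units; within the scatter)). These numbers show how much the group at this position can change the result, but nothing shown here explains why these groups differ.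

Going by these compounds alone, with only one example, it remains open whether the gain belongs to trifluoromethyl itself or to any group at that place on the phenyl ring, and a chlorine, a methyl or a nitrile there would help to separate those two readings. Going by these compounds, it is also open whether the same gain would hold with a shorter or longer chain between the shared core and the ring nitrogen.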